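The source may hold more compounds than are shown below. What is called first, only, known or untested is meant among the compounds shown, and "the series" means these compounds.

Measured so far:
- compound 1 `O=C(O)CN1Cc2ccc(NC(=O)CCCC3CCNCC3)cc2C1=O`: 66000 nM
- compound 2 `CC(CC(=O)O)N1Cc2ccc(NC(=O)c3ccc(C4CCNCC4)cc3)cc2C1=O`: 6200 nM

Compound 1 holds the highest number of the two in a functional assay on a cell-free system (Platelet, plasma, Homo sapiens) for inhibition; on this read-out higher numbers stand for weaker inhibition and lower numbers for stronger inhibition; compound 2 sits well apart from it, and the gap between the two lies beyond the scatter, so compound 1 is the weaker inhibitor of the pair. Going by the values given here, no single-site step joins the two measured compounds, so the series gives no calibrated step to lean on.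

Compound 3 `O=C(O)CCCN1Cc2ccc(NC(=O)CCCC3CCNCC3)cc2C1=O` has yet to be tested in this assay. It differs from compound 1 in one place: 2-carboxyethyl in place of carboxy on a saturated chain carbon bound to an amide-type nitrogen in a ring. The acid-bearing chain on the amide-type nitrogen is thus lengthened while the rest of the core and the piperidine-bearing amide side are kept.

Nothing in the two measurements tells how the acid chain length itself plays out. The step from compound 1 to compound 3 in this assay is therefore expected to be modest, with a slight lean toward stronger inhibition, as a 1.7-fold lower number from compound 1 to compound 3 (0.22 log units; within the scatter). For compound 3 the estimate in this assay is 40000 nM, with a range from 10000 nM to 150000 nM.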

Compound 3, half-maximal inhibitory concentration: 51000 nM
Compound 3: middle estimate off by 1.3-fold (0.11 log units), on the low side; low and high end bracket the measured number.
By their numbers in this assay, from the lowest: compound 2; then compounds 3 and 1 (each within the scatter of the next).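

In this assay, 2-carboxyethyl in place of carboxy on a saturated chain carbon bound to an amide-type nitrogen in a ring gives a 1.3-fold lower number from compound 1 to compound 3 (0.11 log units; within the scatter), the first single-site step the series can be calibrated against. Read the same way, as carboxymethyl to 3-carboxypropyl, the change shows that this position accepts the two chain lengths without a difference that can be told from the scatter, with the core and the piperidine-bearing amide side held constant. No supporting data bear on why the number stays put across this change.

Open, as far as these compounds go, is whether a longer chain than 3-carboxypropyl, or a methyl ester or a tetrazole in place of the carboxylic acid, would move the number beyond the scatter at this position. Also open, from the compounds shown here alone, is whether the same chain change would read alike on the different amide side carried by compound 2, since a step at this position has so far been read only on the amide side shared by compound 1 and compound 3.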